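From Methoxymethoxy to 2-(Methylsulfanyl)ethoxy

The source may report more compounds than this note shows. Statements on the series, on what has been measured and on what is new or still open speak of the compounds shown alone.

In a functional assay on a cell-free system (plasma, Homo sapiens) for inhibition, with Plasma (Rattus norvegicus) as the target (on this read-out lower numbers stand for stronger inhibition and higher numbers for weaker inhibition), compound 1 (`Cc1c(OCc2cccnc2)ccc2c(N3CCNCC3)cc(=O)oc12`) gives 1420 nM, compound 2 (`CCCOc1ccc2c(N3CCNCC3)cc(=O)oc2c1C`) gives 7770 nM and compound 3 (`COCOc1ccc2c(N3CCNCC3)cc(=O)oc2c1C`) gives 3500 nM, the middle of the three numbers. Compound 4 (`CSCCOc1ccc2c(N3CCNCC3)cc(=O)oc2c1C`) carries (methylsulfanyl)methyl in place of methoxy on a saturated chain carbon bound to an oxygen on an aromatic ring. Among the measured compounds shown here, the closest precedent is the modest 2.2-fold lower number from compound 2 to compound 3 (0.35 log units; beyond the scatter), which links two open chains. The steps that remove pyridin-3-yl, a 5.5-fold higher number from compound 1 to compound 2 (0.74 log units; beyond the scatter) and a 2.5-fold higher number from compound 1 to compound 3 (0.39 log units; beyond the scatter), bear less directly on this change. A small move towards the number of compound 2 is therefore expected, probably not beyond the scatter. The expected step is a 1.3-fold higher number from compound 3 to compound 4 (0.11 log units; within the scatter). The estimate for compound 4 is 4500 nM, with an expected range of 1800 nM to 11000 nM.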

Compound 4, half-maximal inhibitory concentration: 1500 nM
Compound 4: middle estimate off by 3.0-fold (0.48 log units), on the high side, and the stated range ends above it.
By their numbers in this assay, from the lowest: compounds 1 and 4 (each within the scatter of the next); then compound 3; then compound 2.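

A simple open chain can stand level with the pyridin-3-yl group at this place: a 1.1-fold higher number from compound 1 to compound 4 (0.02 log units; within the scatter), so no ring on the chain is needed to reach the lowest numbers shown. The 2-(methylsulfanyl)ethoxy chain also separates from both other open chains, with a 2.3-fold lower number from compound 3 to compound 4 (0.37 log units; beyond the scatter) and, for methylsulfanyl in place of methyl, a 5.2-fold lower number from compound 2 to compound 4 (0.71 log units; beyond the scatter). The data shown offer no explanation for these steps. A 2-methoxyethoxy chain, a longer sulfur-bearing chain or an amine at this place would show whether the sulfur or the chain length carries them.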